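Bromo for methyl beside the ring nitrogen in a pyridyl ether

A few compounds are considered here, and "the series" means these few. Any claim that something is new, unique, unknown or untested is made for them only; others in the source may bear on it.

Measured compounds:
Compound 1, `CN1CCC[C@H]1COc1cccnc1`, 0.15 nM
Compound 2, `Cc1ncccc1OC[C@@H]1CCCN1C`, 22.9 nM

In an assay on membranes from brain for displacement of a labelled ligand from Neuronal acetylcholine receptor; alpha4/beta2 (Rattus norvegicus) (on this read-out higher numbers stand for weaker inhibition and lower numbers for stronger inhibition), compound 1 gives 0.15 nM, and compound 2 gives 22.9 nM. Among the measured compounds shown here, on these two numbers compound 2 stands at the higher end, being the weaker of the pair; the only measured step, a 150-fold higher number from compound 1 to compound 2 (2.18 log units; beyond the scatter), is large, so adding a methyl on an aromatic carbon of the shared core costs a great deal in this assay.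

Compound 3, `CN1CCC[C@H]1COc1cccnc1Br`, has not yet been measured. It differs from compound 2 by bromo in place of methyl on an aromatic carbon, the bromo sitting on an aromatic carbon of a six-membered aromatic ring with one nitrogen, next to the ring nitrogen and ortho to a group of eight heavy atoms. For the measured compounds named here, no measured step compares a bromo with a methyl here; the single step available only shows that a substituent at this position is poorly tolerated. The expectation is therefore that compound 3 stays in the range of compound 2 rather than recovering the affinity of compound 1, with an estimated change of a 1.3-fold higher number from compound 2 to compound 3 (0.12 log units; within the scatter) in this assay. Compound 3 is expected to give about 30 nM, somewhere between 5 nM and 200 nM.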

Compound 3, inhibition constant: 451 nM
Compound 3: middle estimate off by 15-fold (1.18 log units), on the low side; the measured number lies above the stated range.
By their numbers in this assay, from the lowest: compound 1; then compound 2; then compound 3.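

In this assay, bromo in place of methyl on this aromatic carbon gives a 20-fold higher number from compound 2 to compound 3 (1.29 log units; beyond the scatter), so two groups of 1 heavy atom each, neither with a hydrogen-bond donor or acceptor, are clearly told apart at this place. Set against hydrogen in compound 1, bromo gives a 3000-fold higher number from compound 1 to compound 3 (3.48 log units; beyond the scatter), well beyond a 150-fold higher number from compound 1 to compound 2 (2.18 log units; beyond the scatter) seen with methyl. The cost of a substituent next to the ring nitrogen is therefore not one fixed penalty for filling the position but depends on which group enters, with the numbers rising from hydrogen through methyl to bromo in these three compounds, and none of them goes against that order.

No measurement shown here bears on the reason bromo costs so much more than methyl. Open too, as far as these compounds go, is where other groups at this place would fall in that order, such as fluoro, which is smaller in atom count of electrons than bromo yet also a halogen, or an amine, and whether any of them would come back towards compound 1.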